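This account rests on a few compounds, and the source may have more. Where it says the series, first, only, none or still open, it means among the compounds named here.

Within the data shown here, in a functional assay on PC-3 cells (Homo sapiens) for inhibition, with a stated time of 48 h, tested at 50 uM (on this read-out lower numbers stand for less inhibition of growth and higher numbers for more inhibition of growth at the one concentration tested), compound 1 (`COc1ccccc1/C=C/[C@@](C)(/C=C/c1ccc(O)cc1)CCC=C(C)C`) gives 46% and compound 2 (`COc1ccc(/C=C/[C@@](C)(/C=C/c2ccc(O)cc2)CCC=C(C)C)cc1`) gives 50% of inhibition, so compound 2 stands within the scatter of the only other measured compound. Compound 3 (`CC(C)=CCC[C@](C)(/C=C/c1ccc(O)cc1)/C=C/c1ccc(F)cc1`) carries fluoro in place of methoxy on an aromatic carbon para to a large group. Among the measured compounds shown here, the only measured step that bears on this (a number 4 percentage points higher from compound 1 to compound 2 (within the scatter)) merely relocates the methoxy group and lies within the scatter. For the measured compounds named here, no measured step replaces methoxy, so no step beyond the scatter is expected in this assay here. The estimated step (a number 2 percentage points lower from compound 2 to compound 3 (within the scatter)) is accordingly expected to be small. Compound 3 is estimated at 48% (expected range 35% to 62%).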

Compound 3, percent growth inhibition at one concentration: 33%
The estimate for compound 3 lay 15 percentage points above the measured number; the whole stated range lies above it.
By their numbers in this assay, from the lowest: compound 3; then compounds 1 and 2 (each within the scatter of the next).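

Exchanging methoxy for fluoro at this position moves the number in this assay: it drops (a number 17 percentage points lower from compound 2 to compound 3 (beyond the scatter)), and the 2-methoxyphenyl compound shows a drop of similar kind (a number 13 percentage points lower from compound 1 to compound 3 (beyond the scatter)). Among the compounds shown, the two methoxy compounds stand within the scatter of each other, while the 4-fluorophenyl compound stands apart from both. Nothing available explains this drop. On these data alone, whether it reflects the loss of methoxy or the arrival of fluoro stays open, as does how a chloro group or an amine would read at this position.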